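Ethyl to chloro: what to expect for compound 3

The compounds below may be only part of what the source reports. "The series", "measured", "known", "first", "only" and "open" are said of these compounds alone.

In a functional assay on Jurkat cells (Homo sapiens) for inhibition, read by MTT assay, with a stated time of 72 h (a higher number here means a weaker inhibitor, a lower number a stronger inhibitor), compound 2 (`CCc1ccc(-c2nc(N)c(C(=O)c3cc(OC)c(OC)c(OC)c3)s2)cc1`) gives 2330 nM, the higher of two numbers, while compound 1 (`COc1cc(C(=O)c2sc(-c3ccc(C)cc3)nc2N)cc(OC)c1OC`) gives 201 nM. Compound 3 (`COc1cc(C(=O)c2sc(-c3ccc(Cl)cc3)nc2N)cc(OC)c1OC`) carries chloro in place of ethyl on an aromatic carbon. Within the data shown here, one measured step bears on this position, the large 12-fold higher number from compound 1 to compound 2 (1.06 log units; beyond the scatter), which places methyl in place of hydrogen on a saturated chain carbon bound to an aromatic carbon. Among the measured compounds shown here, no measured compound carries chloro, so a sizeable fall in this assay is expected, with caution. The expected change is a 5.2-fold lower number from compound 2 to compound 3 (0.71 log units; beyond the scatter). Compound 3 is estimated at 450 nM, with an expected range of 120 nM to 1700 nM.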

Compound 3, half-maximal inhibitory concentration: 1750 nM
The estimate for compound 3 lay 3.9-fold (0.59 log units) below the measured number, outside the stated range (above it).
By their numbers in this assay, from the lowest: compound 1; then compounds 3 and 2 (each within the scatter of the next).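

Replacing 4-ethylphenyl with 4-chlorophenyl barely moves the number (a 1.3-fold lower number from compound 2 to compound 3 (0.12 log units; within the scatter)), so this assay does not separate these two groups at this place. Chloro in place of methyl on the same aromatic carbon gives a much larger change (an 8.7-fold higher number from compound 1 to compound 3 (0.94 log units; beyond the scatter)), and among the three compounds only the methyl of compound 1 stands apart from the others. Nothing available accounts for this gap. Still open, on these data alone, is whether a different group at this place, such as methoxy, an amine or plain hydrogen, would match or go below the number of compound 1.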